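The compounds below may be only part of what the source reports. "The series", "measured", "known", "first", "only" and "open" are said of these compounds alone.

In a functional assay on MCF7 cells (Homo sapiens) for antiproliferative activity, read by MTT assay, with stated times of 24 h and 72 h (on this read-out higher numbers stand for weaker inhibition and lower numbers for stronger inhibition), compound 1 `COc1cc([C@@H]2[C@H](Oc3ccccc3)C(=O)N2c2cc(OC)c(OC)c(OC)c2)cc(OC)c1OC` gives 29000 nM, compound 2 `COc1cc(N2C(=O)[C@@H](Oc3ccccc3)[C@H]2c2ccc(SC)cc2)cc(OC)c1OC` gives 7700 nM and compound 3 `COc1cc(N2C(=O)[C@@H](Oc3ccccc3)[C@H]2c2ccc(N=[N+]=[N-])cc2)cc(OC)c1OC` gives 23000 nM. Compound 3 thus sits in the upper part of these numbers: the record shows a 1.3-fold lower number from compound 1 to compound 3 (0.10 log units; within the scatter), whereas it also shows a 3.0-fold higher number from compound 2 to compound 3 (0.48 log units; beyond the scatter). Compound 4 `COc1cc([C@@H]2[C@H](Oc3ccccc3)C(=O)N2c2cc(OC)c(OC)c(OC)c2)ccc1O` carries 4-hydroxy-3-methoxyphenyl in place of 4-azidophenyl on a saturated ring carbon. Among the measured compounds shown here, no measured step introduces this group, so the nearest guides are the two exchanges made at the same carbon, a 3.8-fold lower number from compound 1 to compound 2 (0.58 log units; beyond the scatter) and a 1.3-fold lower number from compound 1 to compound 3 (0.10 log units; within the scatter). One of these is modest and the other stays within the scatter, and neither is large. In this assay, a large change is therefore not expected, and no clear direction can be drawn from these steps. The expected step, a slight one that does not exceed the scatter, is a 1.5-fold lower number from compound 3 to compound 4 (0.19 log units; within the scatter). For compound 4 the estimated value is 15000 nM, with an expected range from 4000 nM to 45000 nM.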

Compound 4, half-maximal inhibitory concentration: 32000 nM
The estimate for compound 4 lay 2.1-fold (0.33 log units) below the measured number, within the range that was stated.
By their numbers in this assay, from the lowest: compound 2; then compounds 3, 1 and 4 (each within the scatter of the next).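

In this assay, among the compounds shown here, 4-hydroxy-3-methoxyphenyl is the first group on this saturated ring carbon to carry a hydrogen-bond donor, yet the exchange does not separate compound 4 from the azide or the trimethoxy compound: the step of a 1.4-fold higher number from compound 3 to compound 4 (0.14 log units; within the scatter) and the step of a 1.1-fold higher number from compound 1 to compound 4 (0.04 log units; within the scatter) both stay within the scatter. For the compounds shown here, the only step here beyond the scatter is a 4.2-fold higher number from compound 2 to compound 4 (0.62 log units; beyond the scatter) and, with the earlier steps, it leaves 4-(methylsulfanyl)phenyl as the one group of the four that stands apart, with compound 2 giving the lowest number. No measured information accounts for this difference.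

The compounds shown leave open whether ethylsulfanyl in place of methylsulfanyl would keep the lower number of compound 2. They also leave open how a phenyl group carrying an amine or a carboxylic acid would read on this carbon.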